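Removing the Hydroxy from Compound 1

This account rests on a few compounds, and the source may have more. Where it says the series, first, only, none or still open, it means among the compounds named here.

Compound 1 `COc1cc(CC(O)(COCc2ccccc2)COCc2ccccc2)nc(OC)n1` gives only a limit in a functional assay on HepG2 cells (Homo sapiens) for antiproliferative activity, read by MTT assay, with a stated time of 72 h (on this read-out lower numbers stand for stronger inhibition and higher numbers for weaker inhibition), where its reading is > 100000 nM. Compound 2 `COc1nc(CC(O)(COCc2ccccc2)COCc2ccccc2)c(C)c(OC)n1` gives 2400 nM in this assay. Compound 3 `O=c1cc(CC(O)(COCc2ccccc2)COCc2ccccc2)[nH]c(=O)[nH]1` likewise reaches only a limit, namely > 100000 nM. The measured step of an at least 41-fold lower number from compound 1 to compound 2 (1.61 log units; beyond the scatter) came from methyl in place of hydrogen on an aromatic carbon, while the step that the two limits leave unreadable from compound 1 to compound 3 stays unreadable. Compound 1 thus sits at the limit of > 100000 nM in this assay, at which 2 of the 3 values shown sit. Compound 4 `COc1cc(CC(COCc2ccccc2)COCc2ccccc2)nc(OC)n1` differs from compound 1 by hydrogen in place of hydroxy on a saturated chain carbon bound to three saturated chain carbons. For the measured compounds named here, neither measured step touches this saturated chain carbon, so no size of step can be drawn from them. Compound 4 is therefore expected to remain near the limit, the estimated step being a number no higher from compound 1 to compound 4 (the limit leaves the size open). The value of compound 4 is estimated at 100000 nM, within 30000 nM to 300000 nM.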

Compound 4, half-maximal inhibitory concentration: 300 nM
Compound 4: middle estimate off by 330-fold (2.52 log units), on the high side; measured number outside the range, below it.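

Hydrogen in place of hydroxy on a saturated chain carbon bound to three saturated chain carbons gives, in this assay, an at least 330-fold lower number from compound 1 to compound 4 (2.52 log units; beyond the scatter). The earlier steps shown here left this carbon untouched, and this one shows that a large gain can come from here with no change to the shared core. The reading of compound 1 is a limit and not a number: the limit of > 100000 nM in this assay, at which 2 of the 4 values shown sit.

The compounds shown leave open whether a fluorine, an amine or a methoxy on this carbon would serve as hydrogen does. They also leave open whether this change and the methyl of compound 2 would add up in one compound.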